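This account rests on a few compounds, and the source may have more. Where it says the series, first, only, none or still open, it means among the compounds named here.

Measured compounds:
compound 1 `CC(/C=C/CC(C)CCCC(C)C)=C\C(=O)OC(C)C` — 7.15
compound 2 `CC(/C=C/CC(C)CCCC(C)C)=C\C(=O)OC(C)(C)C` — 7.56
compound 3 `CC(/C=C/CC(C)CCCC(C)C)=C\C(=O)Oc1ccccc1` — 7.67

In a physicochemical assay for lipophilicity (on this read-out higher numbers stand for higher lipophilicity and lower numbers for lower lipophilicity), compound 1 gives 7.15, the lowest of the three numbers. Compound 2 stands nearest, with a number 0.41 log units higher from compound 1 to compound 2 (beyond the scatter), and compound 3 furthest, with a number 0.52 log units higher from compound 1 to compound 3 (beyond the scatter). Between compound 2 and compound 3 the numbers lie close together, with a number 0.11 log units higher from compound 2 to compound 3 (within the scatter).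

Compound 4 `COC(CCC(C)C/C=C/C(C)=C/C(=O)OC(C)C)C(C)(C)OC` has not yet been measured in this assay. It differs from compound 1 in this way: 1,2-dimethoxy-2-methylpropyl in place of isobutyl on a saturated chain carbon, four bonds along the chain from a double-bonded chain carbon.

Both measured steps away from compound 1 alter the group on the oxygen of the ester, and both raise the number by a modest amount. Among the measured compounds shown here, neither touches the saturated chain where compound 4 differs, so no measured step bears directly on this change. For the measured compounds named here, the change brings in oxygen where the leaving group carries only carbon, and the measured steps give no precedent for such an exchange. Compound 4 is therefore expected to fall below compound 1 in this assay, with a number 0.85 log units lower from compound 1 to compound 4 (beyond the scatter) as the estimated step, and the width of the range reflects the lack of a direct comparison. For compound 4 the estimate is 6.3, within 5.6 to 7.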

Compound 4, partition coefficient: 4.75
For compound 4 the middle estimate is 1.55 log units above the measured one, outside the stated range (below it).
By their numbers in this assay, from the lowest: compound 4; then compound 1; then compounds 2 and 3 (each within the scatter of the next).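

In this assay, the saturated chain carbon four bonds along the chain from a double-bonded chain carbon proves to be a place where the read-out responds strongly: 1,2-dimethoxy-2-methylpropyl in place of isobutyl gives a number 2.40 log units lower from compound 1 to compound 4 (beyond the scatter). Among the compounds shown here, the earlier changes, which altered the group on an oxygen next to a carbonyl group, were modest and ran upward, with a number 0.41 log units higher from compound 1 to compound 2 (beyond the scatter) and a number 0.52 log units higher from compound 1 to compound 3 (beyond the scatter), so this is the first large step and the first to run downward. The change replaces an isobutyl group with no hydrogen-bond acceptors by a group with 2 hydrogen-bond acceptors, but nothing shown here accounts for the size of the drop.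

The compounds shown leave open whether a single methoxy group, a hydroxyl group or a longer all-carbon chain at this place would move the number as far, and so how much of the step belongs to each part of the entering group. Also open, as far as these compounds go, is whether the same exchange would give a step of similar size in the tert-butyl ester compound 2 or the phenyl ester compound 3.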